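Swapping the halogen-bearing phenyl group

The source may hold more compounds than are shown below. What is called first, only, known or untested is meant among the compounds shown, and "the series" means these compounds.

compound 1 `Oc1ccc2ccccc2c1C(Nc1nc2ccccc2s1)c1cn(-c2ccccc2)nc1-c1ccccc1` - 48900 nM
compound 2 `Oc1ccc2ccccc2c1C(Nc1nc2ccccc2s1)c1cn(-c2ccccc2)nc1-c1cccc(Cl)c1` - 20700 nM
compound 3 `Oc1ccc2ccccc2c1C(Nc1nc2ccccc2s1)c1cn(-c2ccccc2)nc1-c1ccc(I)cc1` - not yet measured

Among the measured compounds shown here, in a functional assay on MCF7 cells (Homo sapiens) for antiproliferative activity, read by MTT assay, with a stated time of 48 h (on this read-out lower numbers stand for stronger inhibition and higher numbers for weaker inhibition), compound 2 gives 20700 nM, the lower of the two numbers so far. Compound 3 carries 4-iodophenyl in place of 3-chlorophenyl on an aromatic carbon. For the measured compounds named here, only one measured step bears on this change, a modest one for chloro in place of hydrogen: a 2.4-fold lower number from compound 1 to compound 2 (0.37 log units; beyond the scatter). Going by the values given here, no measured compound carries iodine, so the direction in this assay stays uncertain, and a step of similarly modest size at most is expected. The estimated step is a 1.1-fold lower number from compound 2 to compound 3 (0.04 log units; within the scatter). For compound 3 the expected value is 19000 nM, with an estimated range of 8000 nM to 45000 nM.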

Compound 3, half-maximal inhibitory concentration: 18900 nM
For compound 3 the middle estimate is 1.0-fold (0.00 log units) above the measured one; the range from low to high includes it.
By their numbers in this assay, from the lowest: compounds 3 and 2 (each within the scatter of the next); then compound 1.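

In this assay, replacing 3-chlorophenyl with 4-iodophenyl leaves the number essentially unchanged, with a 1.1-fold lower number from compound 2 to compound 3 (0.04 log units; within the scatter). Iodine also gives a gain over the unsubstituted phenyl of the parent, with a 2.6-fold lower number from compound 1 to compound 3 (0.41 log units; beyond the scatter), so this position accepts more than one halogen-bearing phenyl. Nothing available explains this result.

Compound 2 and compound 3 differ in both the halogen and its place on the phenyl, so the two changes cannot be separated. As far as these compounds go, whether a methoxy group or an amine on this phenyl would give a similar number remains open.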